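This account rests on a few compounds, and the source may have more. Where it says the series, first, only, none or still open, it means among the compounds named here.

Measured so far, in a functional assay on HCT-116 cells (Homo sapiens) for inhibition; on this read-out lower numbers stand for stronger inhibition and higher numbers for weaker inhibition:
compound 1 `CCNC(=O)c1noc(-c2cc(C(C)C)c(O)cc2O)c1-c1cc(COCC(N)=O)no1`, 97 nM
compound 2 `CCNCc1cc(-c2c(C(=O)NCC)noc2-c2cc(C(C)C)c(O)cc2O)on1`, 45 nM
compound 3 `CCNC(=O)c1noc(-c2cc(C(C)C)c(O)cc2O)c1-c1cc(CN(CC)CC)no1`, 38 nM

Compound 2 stands second highest of the three numbers in this assay. Its nearest neighbour is compound 3, a 1.2-fold lower number from compound 2 to compound 3 (0.07 log units; within the scatter), a gap within the scatter; its furthest is compound 1, a 2.2-fold lower number from compound 1 to compound 2 (0.33 log units; beyond the scatter).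

Compound 4 `CCNC(=O)c1noc(-c2cc(C(C)C)c(O)cc2O)c1-c1cc(CN2CCCCC2)no1` is not yet measured. It differs from compound 2 in one place: piperidin-1-yl in place of ethylamino on a saturated chain carbon bound to an aromatic carbon.

Going by the values given here, the steps that bear on this are those around the amine on the saturated chain carbon bound to the aromatic carbon. Replacing carbamoylmethoxy by an amine gave a 2.2-fold lower number from compound 1 to compound 2 (0.33 log units; beyond the scatter) and a 2.6-fold lower number from compound 1 to compound 3 (0.41 log units; beyond the scatter), both modest. Putting ethyl in place of hydrogen on the amine nitrogen gave a 1.2-fold lower number from compound 2 to compound 3 (0.07 log units; within the scatter), within the scatter. Closing the nitrogen substituents into piperidin-1-yl is therefore expected to change little in this assay: a step of a 1.3-fold lower number from compound 2 to compound 4 (0.11 log units; within the scatter) is expected, small and toward a lower number if anything. Compound 4 is estimated at 35 nM, with a range from 15 nM to 90 nM.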

Compound 4, half-maximal inhibitory concentration: 93 nM
Compound 4: middle estimate off by 2.7-fold (0.42 log units), on the low side; the whole stated range lies below it.
By their numbers in this assay, from the lowest: compounds 3 and 2 (each within the scatter of the next); then compounds 4 and 1 (each within the scatter of the next).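

In this assay, the amine on this saturated chain carbon bound to an aromatic carbon proves not to be freely exchangeable: piperidin-1-yl gives a higher number than either open amine (a 2.1-fold higher number from compound 2 to compound 4 (0.32 log units; beyond the scatter); a 2.4-fold higher number from compound 3 to compound 4 (0.39 log units; beyond the scatter)). An amine at this place therefore does not by itself give the lower numbers of compound 2 and compound 3, as compound 4 goes against that reading and stands level with the carbamoylmethoxy compound (a 1.0-fold lower number from compound 1 to compound 4 (0.02 log units; within the scatter)). No measurement at hand accounts for the difference between the open amines and the ring amine.

Piperidin-1-yl is the only ring amine in this set, so pyrrolidin-1-yl and morpholin-4-yl would show whether the higher number goes with rings in general. Going by these compounds, how a primary aminomethyl group compares at this place also remains open.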